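A hydroxy group on the butyl chain of compound 2

A few compounds are considered here, and "the series" means these few. Any claim that something is new, unique, unknown or untested is made for them only; others in the source may bear on it.

Compound 2 `CCCCCC12CCC(c3nnc(-c4ccccc4C(F)(F)F)n3C)(CC1)CC2` carries a butyl chain on the shared core. In an assay on CHO-K1 cells for inhibition of 11-beta-hydroxysteroid dehydrogenase type 2 (Mus musculus), read by scintillation proximity assay (a lower number here means a stronger inhibitor, a higher number a weaker inhibitor), compound 2 gives > 4000 nM, which is a limit of the assay and not a number. Compound 1 `Cn1c(-c2ccccc2C(F)(F)F)nnc1C12CCC(COc3ccc(S(C)(=O)=O)cc3)(CC1)CC2` differs from compound 2 in one place, and in this assay compound 1 gives > 4000 nM, again a limit rather than a number. The step that the two limits leave unreadable from compound 1 to compound 2 cannot be read, since (the limit of > 4000 nM in this assay, at which 2 of the 2 values shown sit). Compound 3 `CC(O)CCCC12CCC(c3nnc(-c4ccccc4C(F)(F)F)n3C)(CC1)CC2` is the unmeasured partner of compound 2; the change is hydroxy in place of hydrogen on a saturated chain carbon bound to two saturated chain carbons. Among the measured compounds shown here, no measured step bears on this change, and the only step in the set is unreadable. The chemist therefore expects compound 3 to remain at the same limit in this assay, with an expected step that the limit leaves unreadable from compound 2 to compound 3 that is not readable as a gain or a loss beyond the scatter. The estimate for compound 3 is 8000 nM, with a range from 3000 nM to 30000 nM.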

Compound 3, half-maximal inhibitory concentration: > 4000 nM
Compound 3: only a limit was reported (the forecaster's own chance of this, stated with the estimate: 80%); the middle value lies beyond the limit too.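

No new step can be read among compound 1, compound 2 and compound 3, since all three stand at a limit of this assay: the limit of > 4000 nM in this assay, at which 3 of the 3 values shown sit.

The compounds shown leave open whether hydroxy in place of hydrogen changes inhibition at all, and how the three compare.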